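The source may hold more compounds than are shown below. What is called first, only, known or untested is meant among the compounds shown, and "the series" means these compounds.

Working notes on the series.

Of the compounds shown here, two carry a number so far. Compound 1 `O=C(O)C[C@H](NC(=O)CN(c1nc(Cl)nc2[nH]cnc12)C1CC1)C(=O)O` in a functional assay on the whole organism (Tail, strain ICR) with Mus musculus as the target, in the tail flick test, with a stated time of 120 min, at a dose of 25 umol/kg by the oral route (on this read-out higher numbers stand for a stronger effect at the one dose given and lower numbers for a weaker effect), gives 22%. Compound 2 `CC(C)C[C@H](NC(=O)CN(c1nc(Cl)nc2[nH]cnc12)C1CC1)C(=O)OCc1ccccc1` in this assay gives 8.58%, the lowest of the two numbers, with compound 1 standing higher by a gap beyond the usual scatter. Going by the values given here, no pair of measured compounds differs in one place only, so no single measured step can be read from these two.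

Compound 3 `CC(C)C[C@H](NC(=O)CN(c1nc(Cl)nc2[nH]cnc12)C1CC1)C(=O)O` is not yet measured. It differs from compound 2 in one place: hydrogen in place of benzyl on an oxygen next to a carbonyl group.

Among the compounds with values here, an upward step is expected from compound 2 to compound 3, of the size a number 9.4 percentage points higher from compound 2 to compound 3 (within the scatter), because compound 1, the one measured compound with a free carboxy group, gives 22%. The step could nonetheless stay within the scatter. For compound 3 in this assay a value of 18% is estimated, within a range from 5% to 32%.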

Compound 3, a percentage reported as activity, at one dose (the size of the read-out at that dose, not a potency): 18.7%
Estimate against measurement, compound 3: 0.7 percentage points below; low and high end bracket the measured number.
By their numbers in this assay, from the lowest: compound 2; then compounds 3 and 1 (each within the scatter of the next).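

In this assay, going by these compounds alone, the change from benzyloxycarbonyl to carboxy is the first single change that can be read: a number 10.1 percentage points higher from compound 2 to compound 3 (beyond the scatter). With the carboxy group in place on both compounds, the side chain can also be read, and isopropyl in place of carboxy on a saturated chain carbon gives a number 3.3 percentage points lower from compound 1 to compound 3 (within the scatter), so no order can be set between these two compounds. Nothing measured here accounts for either step.

A methyl ester or a primary amide in place of the carboxy group could show whether the hydrogen itself matters or whether only the benzyl group costs activity. On these data alone, a longer chain or a phenyl group in place of isopropyl remains open, as does any reading beyond the one dose and time given.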